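The compounds below may be only part of what the source reports. "The series", "measured", "known", "first", "only" and "open" are said of these compounds alone.

Compound 1 `CCc1ccccc1-c1cccc(COc2ccc([C@H](CC(=O)O)c3nccn3C)cc2)c1` gives 48 nM in an assay on CHO cells for agonist activity at Free fatty acid receptor 1 (Homo sapiens), read by luminescence, with a stated time of 20 s, in the presence of a further agent that is not named here (on this read-out lower numbers stand for an effect already at smaller amounts and higher numbers for an effect only at larger amounts of compound), compound 2 `Cc1c(Cl)cccc1-c1cccc(COc2ccc([C@H](CC(=O)O)c3nccn3C)cc2)c1` gives 61 nM in this assay, and compound 3 `Cn1ccnc1[C@@H](CC(=O)O)c1ccc(OCc2cccc(-c3ccc(Cl)cc3Cl)c2)cc1` gives 69 nM in this assay, the highest of the three numbers, although it lies within the scatter of both others: a 1.4-fold higher number from compound 1 to compound 3 (0.16 log units; within the scatter) and a 1.1-fold higher number from compound 2 to compound 3 (0.05 log units; within the scatter). Compound 4 `Cc1ccc(F)cc1-c1cccc(COc2ccc([C@H](CC(=O)O)c3nccn3C)cc2)c1` differs from compound 3 by 5-fluoro-2-methylphenyl in place of 2,4-dichlorophenyl on an aromatic carbon. The earlier exchanges of this same aromatic ring, a 1.3-fold higher number from compound 1 to compound 2 (0.10 log units; within the scatter) together with the two steps just named, all stayed within the scatter, so no step beyond the scatter is expected in this assay from compound 3 to compound 4, estimated as a 1.2-fold lower number from compound 3 to compound 4 (0.06 log units; within the scatter). Compound 4 is therefore expected to give about 60 nM, between 25 nM and 145 nM.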

Compound 4, half-maximal effective concentration: 36 nM
Compound 4: the middle estimate sits 1.7-fold (0.22 log units) above what was measured; low and high end bracket the measured number.
By their numbers in this assay, from the lowest: compounds 4, 1, 2 and 3 (each within the scatter of the next).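

In this assay, a fourth substituted phenyl group on an aromatic carbon, meta to a large group, still leaves every step within the scatter: a 1.9-fold lower number from compound 3 to compound 4 (0.28 log units; within the scatter), a 1.7-fold lower number from compound 2 to compound 4 (0.23 log units; within the scatter) and a 1.3-fold lower number from compound 1 to compound 4 (0.12 log units; within the scatter). The first of these is the largest step yet at this position, and even so it does not separate the compounds, which now include a fluorine-bearing ring. No other data bear on this result. On these data alone, whether an amine or a morpholine at this position would give a step beyond the scatter remains open.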